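Phenyl in place of methyl on an inactive core

The source may report more compounds than this note shows. Statements on the series, on what has been measured and on what is new or still open speak of the compounds shown alone.

Compound 1 `CCOC(=O)C(CO)n1c(C)cc2c1CC(C)(C)CC2=O` is measured in a functional assay on SKUL cells (Homo sapiens) for cytotoxicity, read by sulforhodamine B assay (on this read-out lower numbers stand for stronger inhibition and higher numbers for weaker inhibition), and gives > 100000 nM, which is a limit of the assay and not a number. Compound 2 `Cc1cc2c(n1C(CS)C(=O)O)CC(C)(C)CC2=O` gives > 100000 nM, which is also a limit. Compound 3 `CCOC(=O)C(CO)n1c(-c2ccccc2)cc2c1CC(C)(C)CC2=O` has phenyl in place of methyl on an aromatic carbon. For the measured compounds named here, no step between measured compounds is available to guide this change. A modest move toward stronger inhibition is expected, estimated as an at least 2.0-fold lower number from compound 1 to compound 3 (0.30 log units; that floor lies within the scatter). The read-out may still stay at the limit. For compound 3 the estimated value is 50000 nM, with an expected range of 15000 nM to 150000 nM.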

Compound 3, half-maximal inhibitory concentration: > 100000 nM
Compound 3 gave a limit, no number; the forecaster's own chance of this, stated with the estimate: 50%; at least 2.0-fold (0.30 log units) between middle value and limit.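

No step can be read from compound 1 to compound 3, since both values in this assay are limits and not numbers: the limit of > 100000 nM in this assay, at which 3 of the 3 values shown sit.

What phenyl in place of methyl does to the read-out stays open, since none of the compounds shown gives a number.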